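Small Side-Chain Swaps, One Untested Acetamido Group

The compounds below may be only part of what the source reports. "The series", "measured", "known", "first", "only" and "open" are said of these compounds alone.

Measured in an ADME assay on L6 cells (Rattus norvegicus) for inhibition, read by resazurin assay, with a stated time of 72 h; on this read-out higher numbers stand for weaker inhibition and lower numbers for stronger inhibition:
- compound 1 `C[S+]([O-])C[C@H]1O[C@@H](n2cnc3c(N)nc(Cl)nc32)[C@H](O)[C@@H]1O` gives 259000 nM
- compound 2 `CS(=O)(=O)C[C@H]1O[C@@H](n2cnc3c(N)nc(Cl)nc32)[C@H](O)[C@@H]1O` gives 156000 nM
- compound 3 `[N-]=[N+]=NC[C@H]1O[C@@H](n2cnc3c(N)nc(Cl)nc32)[C@H](O)[C@@H]1O` gives 155000 nM

Compound 3 sits level with compound 2 and within the usual scatter of compound 1, so none of the three stands apart from the others. The next compound to be tested is compound 4 `CC(=O)NC[C@H]1O[C@@H](n2cnc3c(N)nc(Cl)nc32)[C@H](O)[C@@H]1O` and it keeps the shared core. Going by the values given here, the one change is acetamido in place of azido on a saturated chain carbon bound to a saturated ring carbon with acetamido in place of azido on a saturated chain carbon bound to a saturated ring carbon.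

Among the compounds with values here, three measured steps bear on this, as each swaps the group at that same place. They read a 1.7-fold lower number from compound 1 to compound 3 (0.22 log units; within the scatter) and a 1.0-fold lower number from compound 2 to compound 3 (0.00 log units; within the scatter) and a 1.7-fold lower number from compound 1 to compound 2 (0.22 log units; within the scatter) and none of them leaves the scatter. Within the data shown here, no measured compound carries acetamido, so this guide is only indirect. A step beyond the scatter is therefore not expected in this assay in either direction. The expected change is a 1.2-fold higher number from compound 3 to compound 4 (0.06 log units; within the scatter) in this estimate. For compound 4 the estimated value is 180000 nM with an expected span from 90000 nM to 360000 nM as the likely range.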

Compound 4, half-maximal inhibitory concentration: 189000 nM
The estimate for compound 4 lay 1.1-fold (0.02 log units) below the measured number, within the range that was stated.
By their numbers in this assay, from the lowest: compounds 3, 2, 4 and 1 (each within the scatter of the next).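

In this assay, acetamido carries a hydrogen-bond donor where azido has none, yet the swap gives a 1.2-fold higher number from compound 3 to compound 4 (0.09 log units; within the scatter), and the comparisons with the other two groups give a 1.2-fold higher number from compound 2 to compound 4 (0.08 log units; within the scatter) and a 1.4-fold lower number from compound 1 to compound 4 (0.14 log units; within the scatter). The earlier compounds had shown only that azido and the two sulfur-containing groups could replace one another within the scatter, whereas these steps extend that result to an amide-type group with a hydrogen-bond donor, on a saturated chain carbon bound to a saturated ring carbon. No accompanying measurement explains why all four groups read alike.

Whether an amine, a carboxylic acid, or a longer chain at this same place would produce a step beyond the scatter remains open, since the four groups shown are all small and uncharged overall or carry no ring. Going by these compounds, all four values also come from this assay, so how these same swaps would read in any other test remains unknown.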